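A Benzyl Swap Near the Assay Limit

The compounds below may be only part of what the source reports. "The series", "measured", "known", "first", "only" and "open" are said of these compounds alone.

In an ADME assay on CCRF-CEM cells (Homo sapiens) for cytotoxicity, with a stated time of 3 days (a lower number here means that less compound is tolerated, a higher number that more compound is tolerated), compound 1 `O=C(OC1C=CC(n2ccc(=O)n(Cc3ccccc3)c2=O)C1)c1ccccc1` gives > 25000 nM, which is a limit of the assay. Compound 2 `Cc1ccc(Cn2c(=O)ccn(C3C=CC(OC(=O)c4ccccc4)C3)c2=O)cc1` gives > 25000 nM, also a limit. Going by the values given here, compound 3 `Cc1ccc(Cn2c(=O)ccn(C3C=CC(OC(=O)c4ccccc4)C3)c2=O)c(C)c1` gives 31000 nM, the only actual number among the three. Compound 4 `O=C(OC1C=CC(n2ccc(=O)n(Cc3cc(F)cc(F)c3)c2=O)C1)c1ccccc1` differs from it by 3,5-difluorophenyl in place of 2,4-dimethylphenyl on a saturated chain carbon bound to an aromatic nitrogen, which amounts to 3,5-difluorobenzyl in place of 2,4-dimethylbenzyl. The measured steps offer no size to carry over: a step that the two limits leave unreadable from compound 1 to compound 2, a step that the limit leaves unreadable from compound 1 to compound 3 and a step that the limit leaves unreadable from compound 2 to compound 3. Among the compounds with values here, none of the measured compounds carries fluorine. The expectation therefore rests on compound 3 at 31000 nM alone. The expected change is a 1.1-fold lower number from compound 3 to compound 4 (0.03 log units; within the scatter), with no shift beyond the scatter in either direction. Compound 4 is estimated at 29000 nM, with an expected range of 14000 nM to 55000 nM.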

Compound 4, half-maximal cytotoxic concentration: 32000 nM
Compound 4: the middle estimate sits 1.1-fold (0.04 log units) below what was measured; low and high end bracket the measured number.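

In this assay, going by these compounds alone, 3,5-difluorophenyl in place of 2,4-dimethylphenyl on a saturated chain carbon bound to an aromatic nitrogen gives a 1.0-fold higher number from compound 3 to compound 4 (0.01 log units; within the scatter) and is the first step at this position with a readable size. It shows that two fluorines can replace two methyls on this ring without a change beyond the scatter. The steps from compound 1 and compound 2 to compound 4 cannot be read, because those two values are limits: the limit of > 25000 nM in this assay, at which 2 of the 4 values shown sit.

The compounds shown leave open whether an amine or a carboxylic acid on this ring, or a longer chain in place of the benzyl group, would move the number beyond the scatter.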